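The compounds below may be only part of what the source reports. "The series", "measured", "known", "first", "only" and "open" are said of these compounds alone.

Working notes on the series. In a functional assay on HeLa cells (Homo sapiens) for antiproliferative activity, read by sulforhodamine B assay (a lower number here means a stronger inhibitor of growth, a higher number a weaker inhibitor of growth), compound 1 (`CCCC[C@@H]1O[C@H](COCc2ccccc2)[C@@H](OCc2ccccc2)[C@H](OCc2ccccc2)[C@H]1O`) gives > 50000 nM, which is a limit and not a number. Compound 2 (`O[C@@H]1[C@@H](OCc2ccccc2)[C@H](OCc2ccccc2)[C@@H](COCc2ccccc2)O[C@H]1CC1CC1`) gives > 50000 nM, also a limit. Compound 2 therefore has no numerical position, and the picture so far is the limit of > 50000 nM in this assay, at which 2 of the 2 values shown sit.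

Compound 3 (`O[C@@H]1[C@@H](OCc2ccccc2)[C@H](OCc2ccccc2)[C@@H](COCc2ccccc2)O[C@H]1CC1CCCCC1`) carries cyclohexyl in place of cyclopropyl on a saturated chain carbon bound to a saturated ring carbon.

For the measured compounds named here, the one measured step that bears on this change is a step that the two limits leave unreadable from compound 1 to compound 2. It changes the same place on the shared core, but it gives no size to carry over. No step beyond the scatter is therefore expected in this assay, in either direction, although the data do not exclude one. This expectation rests on compound 2, which stays at > 50000 nM, a limit.

The expected step is a number no higher from compound 2 to compound 3 (the limit leaves the size open). For compound 3 the estimated value is 50000 nM, with an expected range of 20000 nM to 80000 nM, and another report of only a limit is the likeliest outcome.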

Compound 3, concentration for 50% growth inhibition: 9500 nM
Beside the measured number, compound 3's estimate is 5.3-fold (0.72 log units) above it; measured number outside the range, below it.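

In this assay, for the compounds shown here, the place on a saturated chain carbon bound to a saturated ring carbon now proves able to move the series off its limit, which the earlier compounds could not show: cyclohexyl in place of cyclopropyl gives an at least 5.2-fold lower number from compound 2 to compound 3 (0.72 log units; beyond the scatter), and cyclohexyl in place of propyl gives an at least 5.2-fold lower number from compound 1 to compound 3 (0.72 log units; beyond the scatter). Both steps start from a limit rather than a number, so each size is a minimum and the true step may be larger. Among the groups shown at this place, only cyclohexyl yields a measured number, while propyl and cyclopropyl both stay at the limit: the limit of > 50000 nM in this assay, at which 2 of the 3 values shown sit.

The compounds shown leave open whether the step follows the six-membered ring itself or simply the larger number of carbons, a question that a longer open chain at this place would help to settle. They also leave open whether this place tolerates anything other than plain carbon groups, such as an amine or a carboxylic acid, and whether any group here can go further than cyclohexyl.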